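A few compounds are considered here, and "the series" means these few. Any claim that something is new, unique, unknown or untested is made for them only; others in the source may bear on it.

Measured so far:
- compound 1, `Cc1nn(-c2ccccc2)c2nc(-c3ccc(C(C)C)cc3)c(C#N)c(-c3ccccc3O)c12`: 22600 nM
- compound 2, `Cc1nn(-c2ccccc2)c2nc(-c3ccc(F)cc3)c(C#N)c(-c3ccccc3O)c12`: > 20000 nM

In an ADME assay on BJ cells (Homo sapiens) for cytotoxicity, with a stated time of 72 h (a higher number here means that more compound is needed for the effect, a lower number that less compound is needed), compound 1 gives 22600 nM. Compound 2 gives only a limit of the assay, > 20000 nM, so no number is known for it. The step that the limit leaves unreadable from compound 1 to compound 2 therefore cannot be sized; the reason is the limit of > 20000 nM in this assay, at which 1 of the 2 values shown sits, which hides how far compound 2 really lies from compound 1.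

Compound 3, `CCc1cccc(-c2nc3c(c(C)nn3-c3ccccc3)c(-c3ccccc3O)c2C#N)c1`, differs from compound 2 in one place: 3-ethylphenyl in place of 4-fluorophenyl on an aromatic carbon. For the measured compounds named here, only one measured step touches this position, and it is unreadable, so there is no measured guide to the size or direction of the change from a 4-fluorophenyl to a 3-ethylphenyl group. The nearest point of reference is compound 1, which carries an alkyl group on the same phenyl ring and gives 22600 nM. Compound 3 is expected to land in the same region, which means an expected step that the limit leaves unreadable from compound 2 to compound 3 that can hardly be distinguished from no change, and an estimate for compound 3 of 22000 nM, with a range from 12000 nM to 40000 nM.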

Compound 3, half-maximal effective concentration: > 20000 nM
Compound 3 gave a limit, no number; the forecaster's own chance of this, stated with the estimate: 50%; the middle value lies beyond the limit too.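

In this assay compound 3 gives only a limit, > 20000 nM, and no number. The steps linking compound 3 to compound 1 and to compound 2 therefore cannot be read: the limit of > 20000 nM in this assay, at which 2 of the 3 values shown sit.

The compounds shown leave open how far compound 2 and compound 3 really lie from compound 1, and whether swapping the substituted phenyl group changes this read-out at all.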